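Trimming an Ethoxymethyl to Methoxymethyl on a Brominated Bisphenol

The source may hold more compounds than are shown below. What is called first, only, known or untested is meant among the compounds shown, and "the series" means these compounds.

Two brominated diphenylmethanes have been tested so far in a functional assay on HCT-8 cells (Homo sapiens) for cytotoxicity, read by MTT assay, with a stated time of 96 h; a higher number here means a weaker inhibitor, a lower number a stronger inhibitor. Compound 1 `Oc1cc(Cc2cc(O)c(O)c(Br)c2Br)c(Br)c(Br)c1O` gives 2200 nM in this assay. Compound 2 `CCOCc1cc(O)c(O)c(Br)c1Cc1cc(O)c(O)c(Br)c1Br` gives 2800 nM in this assay, which is the higher of the two numbers; the gap to compound 1 lies within the usual scatter, so the two compounds cannot be told apart on potency.

The next compound, compound 3 `COCc1cc(O)c(O)c(Br)c1Cc1cc(O)c(O)c(Br)c1Br`, has not yet been measured in this assay. It differs from compound 2 in a single place: hydrogen in place of methyl on a saturated chain carbon bound to an oxygen on a saturated carbon. The ethoxymethyl side chain of compound 2 becomes a methoxymethyl, and everything else in the shared core is kept.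

Among the measured compounds shown here, no pair of measured compounds shows the effect of this exact change, so there is nothing to copy from. A shortening of a small ether chain by one carbon on the edge of the molecule is expected to move the number little, if at all, in this assay, so the expected step from compound 2 to compound 3 is no change at the digits printed from compound 2 to compound 3 (within the scatter), essentially none beyond the scatter. Compound 3 is therefore estimated at 2800 nM in this assay, with a range from 1400 nM to 5600 nM.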

Compound 3, half-maximal inhibitory concentration: 5900 nM
The estimate for compound 3 lay 2.1-fold (0.32 log units) below the measured number, outside the stated range (above it).
By their numbers in this assay, from the lowest: compounds 1 and 2 (each within the scatter of the next); then compound 3.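

In this assay, the end of this side chain turns out not to be a silent spot: trimming ethoxymethyl to methoxymethyl brings a 2.1-fold higher number from compound 2 to compound 3 (0.32 log units; beyond the scatter). The change removes only a methyl, a single carbon with no hydrogen-bond donor or acceptor and no charge, on a saturated chain carbon bound to an oxygen, yet that small edit is enough to leave a weaker inhibitor in this cell test, so for this pair the ethoxymethyl form is the better one. Nothing at hand explains the shift.

From the compounds shown here alone, a single pair gives a direction for one edit and not a trend, so it remains open whether a longer chain such as propoxymethyl would lower the number, or whether a hydroxymethyl or an aminomethyl group in this place would hold up as well as the ethers do. Going by these compounds, it also remains open whether the same trim would have a similar effect on a different shared core or in other cell lines.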